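Methyl to Hydrogen on the Aromatic Oxygen of Compound 2

The source may hold more compounds than are shown below. What is called first, only, known or untested is meant among the compounds shown, and "the series" means these compounds.

Of the compounds shown here, two sharing one core have been measured in a functional assay on MCF7 cells (Homo sapiens) for cytotoxicity, read by sulforhodamine B assay, with a stated time of 48 h, tested at 1 uM; a lower number here means a stronger effect, a higher number a weaker effect of the compound at the concentration tested. Compound 1, `Cc1cc(O)cc(-c2nn(CC#N)cc2-c2ccnc(-c3ccc(Oc4ccccc4)cc3)c2)c1`, gives -34% in this assay. Compound 2, `COc1cc(C)cc(-c2nn(CC#N)cc2-c2ccnc(-c3ccc(N(C)C)cc3)c2)c1`, gives 7% in this assay, the higher of the two numbers; the gap between compound 2 and compound 1 is beyond the scatter, so compound 2 shows the weaker effect of the pair. Compound 3, `Cc1cc(O)cc(-c2nn(CC#N)cc2-c2ccnc(-c3ccc(N(C)C)cc3)c2)c1`, has not yet been measured. It differs from compound 2 in one place: hydrogen in place of methyl on an oxygen on an aromatic ring. Within the data shown here, no step between measured compounds is available for this change, and compound 1 and compound 3 differ elsewhere, so the two values of compound 1 and compound 3 can only be set side by side once both are known. Compound 1 does carry the hydroxy group and gives the lower number. On that basis the estimated step is a number 19 percentage points lower from compound 2 to compound 3 (beyond the scatter), a moderate downward shift, though a result within the scatter would not surprise. Compound 3 is therefore estimated at -12% in this assay, within a range from -45% to 20%.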

Compound 3, a percentage reported as activity, at one concentration (the size of the read-out at that concentration, not a potency): 10%
The estimate for compound 3 lay 22 percentage points below the measured number, and the stated range covers the measured number.
By their numbers in this assay, from the lowest: compound 1; then compounds 2 and 3 (each within the scatter of the next).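

In this assay the exchange of methoxy for hydroxy reads as a number 3 percentage points higher from compound 2 to compound 3 (within the scatter), so with dimethylamino held in place, hydrogen in place of methyl on this oxygen gives no shift that can be told from the scatter. The earlier pair could not show this, since compound 1 and compound 2 differ in more than one place. Compound 1 and compound 3 share the hydroxy group and differ only in dimethylamino in place of phenoxy on an aromatic carbon, and that change comes with a number 44 percentage points higher from compound 1 to compound 3 (beyond the scatter), so the large gap in this series goes with that exchange and not with the one on the oxygen. Nothing measured here gives a reason for either step.

Whether methoxy and hydroxy would also sit within the scatter of each other with phenoxy in place of dimethylamino remains open, as the shown compounds offer no such pair. Also open, as far as these compounds go, is how a longer chain on this oxygen, such as ethoxy, or an amine or a fluorine in place of the whole hydroxy group, would read in this assay.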